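Replacing 4-hydroxyphenyl with 2,4-difluorophenyl in compound 3

The source may report more compounds than this note shows. Statements on the series, on what has been measured and on what is new or still open speak of the compounds shown alone.

Measured so far in a functional assay on UACC-62 cells (Homo sapiens); on this read-out higher numbers stand for weaker inhibition of growth and lower numbers for stronger inhibition of growth:
- compound 1 `O=S(=O)(/C=C/c1ccc(F)cc1F)Cc1ccc(Nc2ncnc3ccccc23)cc1` gives > 100000 nM as a limit, not a number
- compound 2 `O=S(=O)(/C=C/c1ccc(Cl)c(Cl)c1)Cc1ccc(Nc2ncnc3ccc(Br)cc23)cc1` gives 30000 nM
- compound 3 `O=S(=O)(/C=C/c1ccc(O)cc1)Cc1ccc(Nc2ncnc3ccc(Br)cc23)cc1` gives 28000 nM

Going by the values given here, compound 3 and compound 2 hold the only two true numbers, and these lie within the scatter of each other. Compound 4 `O=S(=O)(/C=C/c1ccc(F)cc1F)Cc1ccc(Nc2ncnc3ccc(Br)cc23)cc1` follows from compound 3 by putting 2,4-difluorophenyl in place of 4-hydroxyphenyl on a double-bonded chain carbon bound to a double-bonded chain carbon. Among the compounds with values here, the one measured step at that place (a 1.1-fold lower number from compound 2 to compound 3 (0.03 log units; within the scatter)) exchanged 3,4-dichlorophenyl for 4-hydroxyphenyl and stayed small. Compound 1 also carries 2,4-difluorophenyl, and its reading (> 100000 nM) is a limit. No change beyond the scatter is therefore expected in this assay for this swap (a 1.1-fold higher number from compound 3 to compound 4 (0.06 log units; within the scatter)). Compound 4 is estimated at 32000 nM with an expected range (from 12000 nM to 90000 nM).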

Compound 4, concentration for 50% growth inhibition: 3000 nM
Compound 4: middle estimate off by 11-fold (1.03 log units), on the high side; measured number outside the range, below it.
By their numbers in this assay, from the lowest: compound 4; then compounds 3 and 2 (each within the scatter of the next). At a limit, above all of these: compound 1.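

In this assay, the group on this double-bonded chain carbon now clearly matters: 2,4-difluorophenyl gives a real change (a 9.3-fold lower number from compound 3 to compound 4 (0.97 log units; beyond the scatter)) and (a 10-fold lower number from compound 2 to compound 4 (1.00 log units; beyond the scatter)), although the two earlier groups had stayed within the scatter of each other. With 2,4-difluorophenyl kept, bromo in place of hydrogen on an aromatic carbon also counts (an at least 33-fold lower number from compound 1 to compound 4 (1.52 log units; beyond the scatter)). Compound 1 reads as a limit, not a number: the limit of > 100000 nM in this assay, at which 1 of the 4 values shown sits. Still open, on these data alone, is how an amine or a carboxylic acid at this place would read, and whether bromo brings a similar change alongside 4-hydroxyphenyl or 3,4-dichlorophenyl.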